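Compound 4: 2-fluorobenzyl in place of 2,5-dimethylphenyl

The source may report more compounds than this note shows. Statements on the series, on what has been measured and on what is new or still open speak of the compounds shown alone.

In a functional assay on HeLa cells (Homo sapiens) for inhibition, read by MTT assay, with a stated time of 48 h (a higher number here means a weaker inhibitor, a lower number a stronger inhibitor), compound 1 (`COc1ccc2c(=O)c(/C=C/C(=O)Nc3cccc(C)c3)coc2c1`) gives > 100000 nM as a limit of the assay, not a number. Compound 2 (`COc1ccc(CNC(=O)/C=C/c2coc3cc(O)ccc3c2=O)cc1`) also gives > 100000 nM as a limit. Within the data shown here, compound 3 (`COc1ccc2c(=O)c(/C=C/C(=O)Nc3cc(C)ccc3C)coc2c1`) gives 58400 nM as the only true number of the three. Most of the readings thus rest on one ceiling (the limit of > 100000 nM in this assay, at which 2 of the 3 values shown sit) and leave little to compare.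

Among the measured compounds shown here, compound 4 (`COc1ccc2c(=O)c(/C=C/C(=O)NCc3ccccc3F)coc2c1`) keeps the core of compound 3 but carries 2-fluorobenzyl in place of 2,5-dimethylphenyl on an amide-type nitrogen as its one change. For the measured compounds named here, the only measured step (an at least 1.7-fold lower number from compound 1 to compound 3 (0.23 log units; that floor lies within the scatter)) is methyl in place of hydrogen on an aromatic carbon, and it does not clear the scatter. Going by the values given here, no measured step covers the swap itself, so no large move is expected, only a small drift towards the ceiling. The expected change is a 1.5-fold higher number from compound 3 to compound 4 (0.16 log units; within the scatter) in this assay and should stay within the scatter. For compound 4 the estimated value is 85000 nM with an expected range from 40000 nM to 160000 nM and a real chance of reading only as a limit.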

Compound 4, half-maximal inhibitory concentration: > 100000 nM
Compound 4: no number, only a limit; the forecaster's own chance of this, stated with the estimate: 55%; middle value at least 1.1-fold (0.07 log units) away from the limit.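

In this assay, placing 2-fluorobenzyl on the amide-type nitrogen in place of 2,5-dimethylphenyl gives an at least 1.7-fold higher number from compound 3 to compound 4 (0.23 log units; that floor lies within the scatter). This is the first step shown at this position, and it takes the only compound with a true number back to a limit, even though the two groups have the same number of heavy atoms, so only the floor of the step is known and that floor stays within the scatter. The step from compound 1 to compound 4 joins two limits and cannot be read, and the series now rests even more on one ceiling: the limit of > 100000 nM in this assay, at which 3 of the 4 values shown sit.

Going by these compounds, it remains open whether a plain benzyl, or a group carrying an amine or a carboxylic acid, on that nitrogen would give a true number. On these data alone, with compound 3 alone still giving a number, the full size of any change here also stays unknown.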